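This account rests on a few compounds, and the source may have more. Where it says the series, first, only, none or still open, it means among the compounds named here.

Notes on the series: in an ADME assay on microsomes from liver (Rattus norvegicus) for metabolic stability, read by LC-MS, with a stated time of 10 min, tested at 0.5 uM (a lower number here means that less of the compound is left, a higher number that more of the compound is left), compound 1 `CCN1CCN(CCCN(C[C@H]2Cc3ccccc3CN2)[C@H]2CCCc3cccnc32)CC1` gives 1%, the lower of the two numbers so far, while compound 2 `c1cnc2c(c1)CN[C@@H](CN(CCCN1CCNCC1)[C@H]1CCCc3cccnc31)C2` gives 79%, a gap beyond the scatter. Among the measured compounds shown here, these two compounds differ in more than one place, so no single-change step has been measured. Compound 3 `CN1CCN(CCCN(C[C@H]2Cc3ccccc3CN2)[C@H]2CCCc3cccnc32)CC1` differs from compound 1 by hydrogen in place of methyl on a saturated chain carbon bound to an amine nitrogen in a ring, with 4-ethylpiperazin-1-yl becoming 4-methylpiperazin-1-yl. A small rise in this assay, within the scatter, is expected, and the estimated step is a number 4 percentage points higher from compound 1 to compound 3 (within the scatter). For compound 3 the estimated value is 5%, with an expected range of 1% to 20%.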

Compound 3, percent of the compound remaining: 10%
Beside the measured number, compound 3's estimate is 5 percentage points below it; measured number inside the range.
By their numbers in this assay, from the lowest: compounds 1 and 3 (each within the scatter of the next); then compound 2.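

In this assay, among the compounds shown here, exchanging 4-ethylpiperazin-1-yl for 4-methylpiperazin-1-yl gives a number 9 percentage points higher from compound 1 to compound 3 (within the scatter), the first single-change reading at this position. Removing this one methyl from the saturated chain carbon bound to an amine nitrogen in a ring therefore leaves the read-out within the scatter on the core of compound 1. No supporting data at hand address the origin of this result. From the compounds shown here alone, how an acetyl or 2-hydroxyethyl group on that piperazine nitrogen would read on this core remains open.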